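This account rests on a few compounds, and the source may have more. Where it says the series, first, only, none or still open, it means among the compounds named here.

In an ADME assay (liver) for metabolic stability, with Liver microsome (Homo sapiens) as the target, read by LC-MS, using microsomes, with a stated time of 30 min, tested at 4 uM (on this read-out higher numbers stand for a more stable compound and lower numbers for a less stable compound), compound 1 `CCN1CCN(c2nc(C)nc3c2nc(-c2ccccc2Cl)n3C)CC1` gives 7% as the share left at the end of the test. On the same scale compound 2 `Cc1nc(N2CCN(C)CC2)c2nc(-c3ccccc3Cl)n(CCO)c2n1` gives 13% as its share. These two numbers lie within the usual scatter of each other, so they count as one result, and both stand near the low end of the scale. Compound 3 `CCN1CCN(c2nc(C)nc3c2nc(-c2ccccc2Cl)n3CCOC)CC1` has not been measured yet. It differs from compound 1 in one place: methoxymethyl in place of hydrogen on a saturated chain carbon bound to an aromatic nitrogen. In words, this is methoxymethyl in place of hydrogen on a saturated chain carbon bound to an aromatic nitrogen, and the same difference also reads as methyl to 2-methoxyethyl. For the measured compounds named here, no measured pair shows what such a change does, so there is no direct evidence for its size or direction. The estimated step of a number 2 percentage points higher from compound 1 to compound 3 (within the scatter) is expected to stay within the scatter, with no direction that could be called. That expectation rests only on compound 1 at 7% and compound 2 at 13% as the available guides. Compound 3 is therefore expected to give 9% in this assay, with an estimated range of 3% to 20% for the measurement.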

Compound 3, percent of the compound remaining: 31%
For compound 3 the middle estimate is 22 percentage points below the measured one; the measured number lies above the stated range.
By their numbers in this assay, from the lowest: compounds 1 and 2 (each within the scatter of the next); then compound 3.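

In this assay, the substituent on the aromatic nitrogen of the shared core proves able to shift the result: extending methyl to 2-methoxyethyl, with the rest of compound 1 unchanged, gives a number 24 percentage points higher from compound 1 to compound 3 (beyond the scatter). For the compounds shown here, this is the first pair to isolate a change at this position, and it shows that methoxymethyl in place of hydrogen on this saturated chain carbon can raise the share of compound left by a modest but readable amount, although compound 3 at 31% still remains in the lower part of the scale. Nothing available explains why this happens, and no supporting measurement bears on the result.

On these data alone, a single pair cannot separate the effect of the longer chain from that of the oxygen it carries, so it remains open whether a plain propyl chain, made of carbon atoms alone, would give a similar step. As far as these compounds go, it also remains open whether the step would persist with a longer ether chain such as 3-methoxypropyl, or with a different end group such as a carboxylic acid or an amine.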